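Swapping the Fluorinated Ring for a Brominated One

The source may report more compounds than this note shows. Statements on the series, on what has been measured and on what is new or still open speak of the compounds shown alone.

Compound 1 `COc1cc(OC)c(-c2coc3cc(OCc4ccc(F)cc4)ccc3c2=O)cc1OC` is measured in a functional assay on HepG2 cells (Homo sapiens) for antiproliferative activity, read by MTT assay, with a stated time of 24 h (on this read-out lower numbers stand for stronger inhibition and higher numbers for weaker inhibition), and gives 1000 nM; among the three measured compounds it holds the second highest number, nearest to compound 3 `COc1cc(OC)c(-c2coc3cc(OCc4cccc(Br)c4)ccc3c2=O)cc1OC` with 870 nM and furthest from compound 2 `COc1cc(OC)c(-c2coc3cc(OCc4ccccc4C)ccc3c2=O)cc1OC` with 1860 nM. Compound 4 `COc1cc(OC)c(-c2coc3cc(OCc4ccccc4Br)ccc3c2=O)cc1OC` is not yet measured and differs from compound 1 by 2-bromophenyl in place of 4-fluorophenyl on a saturated chain carbon bound to an oxygen on an aromatic ring. For the measured compounds named here, two measured steps bear on this change: a 1.9-fold higher number from compound 1 to compound 2 (0.27 log units; within the scatter) and a 1.1-fold lower number from compound 1 to compound 3 (0.06 log units; within the scatter). Neither moved beyond the scatter, and a 2.1-fold lower number from compound 2 to compound 3 (0.33 log units; beyond the scatter) was only modest. Compound 4 combines the bromine seen in compound 3 with a ring substituted as in compound 2, so little movement is expected. The expected step is a 1.3-fold higher number from compound 1 to compound 4 (0.11 log units; within the scatter). Compound 4 is therefore estimated at 1300 nM, within 600 nM to 2800 nM.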

Compound 4, half-maximal inhibitory concentration: 2180 nM
Compound 4: middle estimate off by 1.7-fold (0.22 log units), on the low side, within the range that was stated.
By their numbers in this assay, from the lowest: compounds 3, 1, 2 and 4 (each within the scatter of the next, the first and the last beyond it).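

Where the bromine sits on the ring matters here: 2-bromophenyl in place of 3-bromophenyl gives a 2.5-fold higher number from compound 3 to compound 4 (0.40 log units; beyond the scatter), and 2-bromophenyl in place of 4-fluorophenyl gives a 2.2-fold higher number from compound 1 to compound 4 (0.34 log units; beyond the scatter), both modest steps. Bromo in place of methyl on an aromatic carbon gives a 1.2-fold higher number from compound 2 to compound 4 (0.07 log units; within the scatter), so the 2-bromophenyl and 2-methylphenyl groups read alike. Nothing available explains these differences. Going by these compounds, it remains open whether a 2-chlorophenyl or 2-methoxyphenyl group would read like these two, and whether a 4-bromophenyl group would read like the 3-bromophenyl one.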